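Methoxy in Place of Trifluoromethyl: Expected Cytotoxicity

The source may hold more compounds than are shown below. What is called first, only, known or untested is meant among the compounds shown, and "the series" means these compounds.

Four compounds share one core and differ in a single group. In an ADME assay on MRC5 cells (Homo sapiens) for cytotoxicity, read by fluorescence and resazurin assay, with a stated time of 3 days (on this read-out higher numbers stand for weaker inhibition and lower numbers for stronger inhibition), compound 1 `Cc1cn(C2CCN(Cc3cccc(Oc4cc(C(F)(F)F)cc(C(F)(F)F)c4)c3)CC2)c(=O)[nH]c1=O` gives "not determined" (no result reported) and compound 2 `Cc1cn(C2CCN(Cc3cccc(Oc4ccncc4)c3)CC2)c(=O)[nH]c1=O` gives "not determined" (no result reported), so nothing can be said of them. Going by the values given here, compound 3 `Cc1cn(C2CCN(Cc3cccc(Oc4cccc(C(F)(F)F)c4)c3)CC2)c(=O)[nH]c1=O` is the only one with a number: in this assay compound 3 gives 12400 nM, and with no second measured compound it stands alone, without any step to compare against. Compound 4 `COc1cccc(Oc2cccc(CN3CCC(n4cc(C)c(=O)[nH]c4=O)CC3)c2)c1` differs from compound 3 in one place: methoxy in place of trifluoromethyl on an aromatic carbon. Among the compounds with values here, no measured step exists here to size this change, so the expected step is a 1.2-fold higher number from compound 3 to compound 4 (0.08 log units; within the scatter), within the usual scatter and with no direction favoured. Compound 4 is therefore estimated at 15000 nM, most likely between 6000 nM and 40000 nM.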

Compound 4, half-maximal inhibitory concentration: 25300 nM
Compound 4: middle estimate off by 1.7-fold (0.23 log units), on the low side; measured number inside the range.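

This gives the series its first measured step: in this assay, methoxy in place of trifluoromethyl on this aromatic carbon brings a 2.0-fold higher number from compound 3 to compound 4 (0.31 log units; beyond the scatter) and so weaker inhibition, a modest change but one beyond the usual scatter. The group on this carbon can therefore move the read-out, although one pair sets no trend. Nothing measured here accounts for the shift. From the compounds shown here alone, whether an amine, a carboxylic acid or a longer chain on the same carbon would move the number further, and in which direction, remains open.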